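Swapping a Hydroxycyclohexyl Amide for a Cyclopropyl Amide

The source may hold more compounds than are shown below. What is called first, only, known or untested is meant among the compounds shown, and "the series" means these compounds.

Compound 1, `CNC(=O)c1cc(C(=O)N[C@H]2CC[C@H](O)CC2)cc2c1OC[C@@]2(C)c1ccccc1`, was tested in a physicochemical assay for solubility (on this read-out higher numbers stand for higher solubility and lower numbers for lower solubility), where compound 1 gives >= 161 ug/mL. That figure is a limit of the assay, not a number. Compound 2, `CNC(=O)c1cc(C(=O)N[C@H]2[C@@H]3COC[C@@H]32)cc2c1OC[C@H]2c1cccnc1`, was tested in the same way, and in this assay compound 2 gives >= 104 ug/mL, which is also a limit of the assay. So compound 1 stands only on a limit, and the single other value shown, at the limit of >= 104 ug/mL in this assay, at which 1 of the 2 values shown sits, is a limit too; no ordering between the two can be read from them.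

Compound 3, `CNC(=O)c1cc(C(=O)NC2CC2)cc2c1OC[C@@]2(C)c1ccccc1`, has not been measured. It differs from compound 1 in one place: cyclopropyl in place of 4-hydroxycyclohexyl on an amide-type nitrogen. For the measured compounds named here, no measured step between the compounds exists to guide the size of this change. The step is nonetheless expected to be a drop beyond the usual scatter, an at least 2.6-fold lower number from compound 1 to compound 3 (0.42 log units; beyond the scatter), since only an expectation is possible here. Compound 3 is therefore estimated at 60 ug/mL, with a likely range from 15 ug/mL to 200 ug/mL.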

Compound 3, solubility: >= 138 ug/mL
Compound 3 was reported as a limit; the forecaster's own chance of this, stated with the estimate: 25%; middle value at least 2.3-fold (0.36 log units) from the limit.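

In this assay compound 3 gives >= 138 ug/mL, which is a limit of the assay. Compound 1 gives >= 161 ug/mL, also a limit. With only these two limits, no step can be read between compound 1 and compound 3. On these data alone, it remains open whether cyclopropyl in place of 4-hydroxycyclohexyl on an amide-type nitrogen shifts this read-out at all.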